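Chloro for Fluoro on the Outer Aromatic Ring

The source may hold more compounds than are shown below. What is called first, only, known or untested is meant among the compounds shown, and "the series" means these compounds.

Compound 2 `CC(C)C[C@H](N)CN(C(=O)[C@@H]1C[C@H]1c1ccccc1)c1ccc(-c2ccccc2F)cc1` gives 1600 nM in a functional assay for agonist activity at G protein-coupled receptor 88 (Homo sapiens), read by HTRF and cAMP accumulation; a higher number here means that more compound is needed for the effect, a lower number that less compound is needed. Among the two measured compounds it carries the highest number, and its only neighbour is compound 1 `CC(C)C[C@H](N)CN(C(=O)[C@@H]1C[C@H]1c1ccccc1)c1ccc(-c2cccs2)cc1`, which gives 1500 nM in this assay; the step of a 1.1-fold higher number from compound 1 to compound 2 (0.03 log units; within the scatter), exchanging thiophen-2-yl for 2-fluorophenyl, lies within the scatter. Compound 3 `CC(C)C[C@H](N)CN(C(=O)[C@@H]1C[C@H]1c1ccccc1)c1ccc(-c2ccccc2Cl)cc1` differs from compound 2 by chloro in place of fluoro on an aromatic carbon of a six-membered aromatic ring of carbon only, ortho to a large group. Going by the values given here, no measured step touches this position. Among the compounds with values here, the single step available, a 1.1-fold higher number from compound 1 to compound 2 (0.03 log units; within the scatter), replaced the whole outer ring without moving the number beyond the scatter, so a smaller change at one atom is expected to behave alike. The step of a 1.1-fold lower number from compound 2 to compound 3 (0.03 log units; within the scatter) is therefore expected to stay within the scatter. Compound 3 is estimated at 1500 nM, with a range from 600 nM to 4000 nM.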

Compound 3, half-maximal effective concentration: 3800 nM
For compound 3 the middle estimate is 2.5-fold (0.40 log units) below the measured one; the range from low to high includes it.
By their numbers in this assay, from the lowest: compounds 1 and 2 (each within the scatter of the next); then compound 3.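

In this assay, a change of a single atom at this position is enough to move the number: a 2.4-fold higher number from compound 2 to compound 3 (0.38 log units; beyond the scatter) when chloro replaces fluoro on the outer ring. The earlier exchange of the whole ring stayed within the scatter, but a 2.5-fold higher number from compound 1 to compound 3 (0.40 log units; beyond the scatter) with 2-chlorophenyl in place of thiophen-2-yl lies beyond it. A quiet exchange of the outer ring therefore did not mean that this ring accepts any group, as what it carries at this place can matter, though the effect remains modest.

Going by these compounds, whether a methyl or a methoxy group on the same aromatic carbon would give a number closer to that of fluoro or of chloro remains open. Nothing given here explains why chloro and fluoro differ in this assay.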